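The source may hold more compounds than are shown below. What is called first, only, known or untested is meant among the compounds shown, and "the series" means these compounds.

Measured so far in an assay on SHEP1 cells for displacement of a labelled ligand from Neuronal acetylcholine receptor; alpha4/beta2 (Homo sapiens), read by scintillation counting, with a stated time of 2 h; on this read-out lower numbers stand for stronger inhibition and higher numbers for weaker inhibition:
compound 1 `C[C@H]1C[C@H]1C(=O)N1CC2CNCC2C1`, giving 18 nM
compound 2 `O=C(C1CC1)[C@H]1C[C@H]2CNC[C@H]2C1`, giving 0.5 nM
compound 3 `O=C(c1ccco1)[C@H]1C[C@H]2CNC[C@H]2C1`, giving 13 nM

Compound 3 stands second highest of the three numbers in this assay. Its nearest neighbour is compound 1, whose number is within the scatter of that of compound 3, so no order between the two is claimed. Going by the values given here, its furthest is compound 2: the step of a 26-fold higher number from compound 2 to compound 3 (1.41 log units; beyond the scatter) is the only one-place change measured here, and it is large.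

The next compound is compound 4 `COC(=O)[C@H]1C[C@H]2CNC[C@H]2C1`. The change from compound 3 is methoxy in place of furan-2-yl on a carbonyl carbon. Among the compounds with values here, no measured step replaces the carbonyl substituent with an acyclic group, so the step from compound 2 to compound 3 is the only one that bears on it. That step shows that the group on this carbonyl carbon moves the number by a large amount in this assay, and that a small group on it gave the lowest number of the three. On that basis, for compound 4 a lower number than for compound 3 is expected, a step of about a 2.6-fold lower number from compound 3 to compound 4 (0.41 log units; beyond the scatter), though with wide uncertainty since no ester has been measured. The estimate for compound 4 in this assay is 5 nM, with a range from 1 nM to 30 nM.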

Compound 4, inhibition constant: 8 nM
Estimate against measurement, compound 4: 1.6-fold (0.20 log units) below; low and high end bracket the measured number.
By their numbers in this assay, from the lowest: compound 2; then compounds 4, 3 and 1 (each within the scatter of the next, the first and the last beyond it).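

In this assay, the step of a 1.6-fold lower number from compound 3 to compound 4 (0.21 log units; within the scatter) means that methoxy and furan-2-yl on this carbonyl carbon are not told apart, even though a five-membered aromatic ring leaves, no ring enters, and the heavy-atom count falls from 5 to 2. Cyclopropyl stays apart from both groups, as the large step of a 16-fold higher number from compound 2 to compound 4 (1.20 log units; beyond the scatter) shows, so a low heavy-atom count alone does not reproduce the low number of compound 2, and the earlier reading that a small group on this carbon gives a low number holds for cyclopropyl but not for methoxy. The data on these compounds give no measured reason for cyclopropyl standing apart.

Open, on these data alone, is whether an acyclic carbon group such as isopropyl, or a longer chain such as n-butyl, on the carbonyl carbon would fall with cyclopropyl or with methoxy and furan-2-yl. Also open, as far as these compounds go, is how a dimethylamino group or a free carboxylic acid in that place would read in this assay, and whether another small ring such as cyclobutyl would stay with cyclopropyl.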